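A few compounds are considered here, and "the series" means these few. Any claim that something is new, unique, unknown or untested is made for them only; others in the source may bear on it.

Measured set in a functional assay with Alpha-1B adrenergic receptor (Homo sapiens) as the target, read by calcium flux; on this read-out higher numbers stand for larger maximal responses and lower numbers for smaller maximal responses:
- compound 1 `Cn1nccc1-c1ccccc1NCC1=NCCN1`, 0%
- compound 2 `c1ccc(-c2cn[nH]c2)c(NCC2=NCCN2)c1`, 72%
- compound 3 `Cn1ncnc1-c1ccccc1NCC1=NCCN1`, 93%

Compound 3 stands highest of the three in this assay; its nearest neighbour is compound 2, and compound 1 lies furthest below it. Compound 4 `Cn1ccnc1-c1ccccc1NCC1=NCCN1` differs from compound 3 only at the five-membered ring on the shared core: 1-methyl-1H-imidazol-2-yl in place of 1-methyl-1H-1,2,4-triazol-5-yl on an aromatic carbon. Among the compounds with values here, two measured steps bear on this position. The exchange of that ring gave a number 93 percentage points higher from compound 1 to compound 3 (beyond the scatter) and a number 21 percentage points higher from compound 2 to compound 3 (beyond the scatter), so the ring identity moves the maximal response strongly, and the drop from compound 3 is expected to be a number 33 percentage points lower from compound 3 to compound 4 (beyond the scatter). Compound 4 is therefore estimated at 60%, with a range from 10% to 100%.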

Compound 4, largest response reached (reported as maximal response), in percent of the reference or control that the assay uses: 104%
The estimate for compound 4 lay 44 percentage points below the measured number; the measured number lies above the stated range.
By their numbers in this assay, from the lowest: compound 1; then compound 2; then compound 3; then compound 4.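

In this assay, 1-methyl-1H-imidazol-2-yl in place of 1-methyl-1H-1,2,4-triazol-5-yl gives a number 11 percentage points higher from compound 3 to compound 4 (beyond the scatter) and shows that the triazole did not mark the top of the series at this position. The same group gives a number 32 percentage points higher from compound 2 to compound 4 (beyond the scatter) and a number 104 percentage points higher from compound 1 to compound 4 (beyond the scatter) and so places the widest gap between two methylated five-membered rings. No measurement available here accounts for these differences.

Open remains how an ethyl group in place of the methyl on the imidazole would read. Going by these compounds, a pyridyl ring or an aminomethyl group on this aromatic carbon is likewise open.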